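Hydrogen for methyl on the fluorophenyl member of the series

The source may hold more compounds than are shown below. What is called first, only, known or untested is meant among the compounds shown, and "the series" means these compounds.

Compound 2 `C=C1CC(Cn2cc(C)c(=O)[nH]c2=O)(c2ccc(F)cc2)OC1=O` stands highest of the three numbers recorded so far in a functional assay on MDA-MB-435 cells (Homo sapiens) for inhibition (on this read-out lower numbers stand for stronger inhibition of growth and higher numbers for weaker inhibition of growth), giving 5620 nM. Compound 1 `C=C1CC(Cn2cc(C)c(=O)[nH]c2=O)(c2ccc(-c3ccccc3)cc2)OC1=O` gives 2000 nM in this assay, and compound 3 `C=C1CC(Cn2ccc(=O)[nH]c2=O)(c2ccc(-c3ccccc3)cc2)OC1=O` gives 490 nM. Two single-point steps connect these: a 2.8-fold higher number from compound 1 to compound 2 (0.45 log units; beyond the scatter), where fluoro replaces phenyl on an aromatic carbon, and a 4.1-fold lower number from compound 1 to compound 3 (0.61 log units; beyond the scatter), where hydrogen replaces methyl on an aromatic carbon. Compound 2 is therefore separated from compound 1 by one change and from compound 3 by two.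

Compound 4 `C=C1CC(Cn2ccc(=O)[nH]c2=O)(c2ccc(F)cc2)OC1=O` is the remaining corner of this square. It differs from compound 2 by hydrogen in place of methyl on an aromatic carbon. Going by the values given here, the step that bears directly on it is the one from compound 1 to compound 3, which applied the same replacement on the phenyl-bearing core and lowered the number beyond the scatter. Among the compounds with values here, no measured step shows how the change behaves on the fluoro-bearing core, so the expectation rests on that single precedent and on the assumption that the two changes act independently. A step of comparable size in the same direction is expected, a 4.0-fold lower number from compound 2 to compound 4 (0.60 log units; beyond the scatter), with the uncertainty widened to allow for the second change. For compound 4 the estimated value in this assay is 1400 nM, within a range from 600 nM to 3500 nM.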

Compound 4, concentration for 50% growth inhibition: 10700 nM
Compound 4: the middle estimate sits 7.6-fold (0.88 log units) below what was measured; measured number outside the range, above it.
By their numbers in this assay, from the lowest: compound 3; then compound 1; then compounds 2 and 4 (each within the scatter of the next).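

Notes on the hydrogen-for-methyl change: on the core of compound 2, hydrogen in place of methyl on the six-membered aromatic ring with 2 nitrogen gives no step beyond the scatter in this assay, a 1.9-fold higher number from compound 2 to compound 4 (0.28 log units; within the scatter), so the lower number seen with this change on the core of compound 1 does not carry over: the same change on two cores in this assay, a 4.1-fold lower number (0.61 log units; beyond the scatter) from compound 1 to compound 3 and a 1.9-fold higher number (0.28 log units; within the scatter) from compound 2 to compound 4, 7.8-fold (0.89 log units) apart, beyond the scatter of two such steps

Read along the other edge of the square, fluoro in place of phenyl gives a 22-fold higher number from compound 3 to compound 4 (1.34 log units; beyond the scatter), a much larger step with hydrogen at this position than with methyl: the same change on two cores in this assay, a 2.8-fold higher number (0.45 log units; beyond the scatter) from compound 1 to compound 2 and a 22-fold higher number (1.34 log units; beyond the scatter) from compound 3 to compound 4, 7.8-fold (0.89 log units) apart, beyond the scatter of two such steps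

The two changes are therefore not independent across these four compounds, and the outcome of removing the methyl depends on whether phenyl or fluoro is carried on the other aromatic ring.

As far as these compounds go, this coupling rests on a single square, so it remains open whether a core carrying chloro or methoxy in place of phenyl would follow compound 1 and compound 3 or compound 2 and compound 4. Also open, from the compounds shown here alone, is how an ethyl group or an amine at the position of the methyl would behave on either core.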